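Moving the Bromine to a New Place on the Ring

The compounds below may be only part of what the source reports. "The series", "measured", "known", "first", "only" and "open" are said of these compounds alone.

Of the compounds shown here, three sharing one core have been tested in an assay on CHO cells for displacement of a labelled ligand from transient receptor potential cation channel subfamily V member 1 (Rattus norvegicus); on this read-out higher numbers stand for weaker inhibition and lower numbers for stronger inhibition. Compound 1 `COc1cc(CNC(=S)NC(CCc2ccc(C(C)(C)C)cc2)COC(=O)C(C)(C)C)c(Br)cc1O` gives 75 nM. Compound 2 `COc1cc(CNC(=S)NC(CCc2ccc(C)c(C)c2)COC(=O)C(C)(C)C)cc(Cl)c1O` gives 86 nM. Compound 3 `COc1cc(CNC(=S)NC(CCc2ccc(C)c(C)c2)COC(=O)C(C)(C)C)cc(Br)c1O` gives 102 nM. These three numbers lie within the usual scatter of one another, so compound 3 cannot be set apart from the other two. Within the data shown here, the only single-point step among them, a 1.2-fold higher number from compound 2 to compound 3 (0.07 log units; within the scatter), shows that exchanging one halogen for the other leaves the number essentially unchanged.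

Compound 4 `COc1cc(CNC(=S)NC(CCc2ccc(C)c(C)c2)COC(=O)C(C)(C)C)c(Br)cc1O` is the next candidate. It differs from compound 3 by 2-bromo-4-hydroxy-5-methoxyphenyl in place of 3-bromo-4-hydroxy-5-methoxyphenyl on a saturated chain carbon bound to an amide-type nitrogen; the bromine simply moves to another position on the same ring. Among the measured compounds shown here, no measured pair isolates this move. Compound 1 does carry its bromine at the 2-position and gives 75 nM, but it also differs from compound 4 in a second place, so it offers only indirect support. The step from compound 3 to compound 4 is therefore expected to be small, about a 1.2-fold lower number from compound 3 to compound 4 (0.08 log units; within the scatter), in no clear direction. The estimate for compound 4 is 85 nM, with a range from 35 nM to 210 nM.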

Compound 4, inhibition constant: 109 nM
Estimate against measurement, compound 4: 1.3-fold (0.11 log units) below, and the stated range covers the measured number.
By their numbers in this assay, from the lowest: compounds 1, 2, 3 and 4 (each within the scatter of the next).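

In this assay, the bromine's move from 3-bromo-4-hydroxy-5-methoxyphenyl to 2-bromo-4-hydroxy-5-methoxyphenyl can now be read directly, with nothing else changed (a 1.1-fold higher number from compound 3 to compound 4 (0.03 log units; within the scatter)), so these data do not separate the two placements. The scatter also covers changing halogen and placement together (a 1.3-fold higher number from compound 2 to compound 4 (0.10 log units; within the scatter)), and, with the bromine in its new place, 3,4-dimethylphenyl in place of 4-(tert-butyl)phenyl (a 1.5-fold higher number from compound 1 to compound 4 (0.16 log units; within the scatter)). No measurement available here offers an explanation for these results.

From the compounds shown here alone, whether an iodine or a nitrile in place of the bromine would stay within the same range remains open. Among these compounds, also open is whether the bromine's move would read the same with 4-(tert-butyl)phenyl on the chain, as compound 1 is the only compound here carrying that group.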